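Solubility series: para substituent on the N-aryl ring

The source may hold more compounds than are shown below. What is called first, only, known or untested is meant among the compounds shown, and "the series" means these compounds.

Compound 2 `CS(=O)(=O)NC(=O)CCc1cn(-c2ccccc2)nc1-c1ccc(Cl)cc1` gives 200000 nM in a physicochemical assay for solubility, in phosphate buffer, measured as thermodynamic solubility, at pH 7.4; on this read-out higher numbers stand for higher solubility and lower numbers for lower solubility. Compound 2 stands highest of the three numbers, but only within the scatter: compound 1 `CS(=O)(=O)NC(=O)CCc1cn(-c2ccc(Br)cc2)nc1-c1ccc(Cl)cc1` gives 170000 nM, a step of a 1.2-fold higher number from compound 1 to compound 2 (0.07 log units; within the scatter), and compound 3 `CS(=O)(=O)NC(=O)CCc1cn(-c2ccc(Cl)cc2)nc1-c1ccc(Cl)cc1` gives 100000 nM, a step of a 2.0-fold lower number from compound 2 to compound 3 (0.30 log units; within the scatter). The step from compound 1 to compound 3 is a 1.7-fold lower number from compound 1 to compound 3 (0.23 log units; within the scatter). All three differ only on the aromatic carbon of the six-membered aromatic ring of carbon only, para to a large group, and none of those changes moves solubility beyond the scatter.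

Compound 4 `C[S+]([O-])c1ccc(-n2cc(CCC(=O)NS(C)(=O)=O)c(-c3ccc(Cl)cc3)n2)cc1` differs from compound 2 at that same place: a group of 3 heavy atoms (1 carbon, 1 oxygen, 1 sulfur; no ring) in place of a hydrogen atom, on an aromatic carbon. Among the measured compounds shown here, the entering group has no counterpart among the measured compounds, so no step shows it directly. For the measured compounds named here, the steps that bear on it are those at the same place, which stay within the scatter whether a bromo, a chloro or a hydrogen sits there. The expected step from compound 2 to compound 4 is therefore small, likely within the scatter, with a slight lean toward a higher number that the data neither confirm nor rule out: a 1.5-fold higher number from compound 2 to compound 4 (0.18 log units; within the scatter). Compound 4 is estimated at 300000 nM, with a range from 120000 nM to 800000 nM.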

Compound 4, solubility: 200000 nM
Estimate against measurement, compound 4: 1.5-fold (0.18 log units) above; the measured number falls inside the stated range.
By their numbers in this assay, from the lowest: compounds 3, 1, 2 and 4 (each within the scatter of the next).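

Working notes on the para position: in this assay, the group of 3 heavy atoms (1 carbon, 1 oxygen, 1 sulfur; no ring) brings sulfur and oxygen to this aromatic carbon, yet its steps stay within the scatter against hydrogen (no change at the digits printed from compound 2 to compound 4 (within the scatter)), against chloro (a 2.0-fold higher number from compound 3 to compound 4 (0.30 log units; within the scatter)) and against bromo (a 1.2-fold higher number from compound 1 to compound 4 (0.07 log units; within the scatter)). The earlier compounds shown here covered only hydrogen and two halogens at this place; the flat picture now extends to an entering group of a different composition, and all four compounds lie within the scatter of one another, so this read-out does not separate any of these groups. No supporting measurement is available to account for this result.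

From the compounds shown here alone, whether the picture holds for an amine, a carboxylic acid or a longer chain on the same aromatic carbon stays open. The compounds shown also share the rest of the core unchanged, so they say nothing about how solubility responds to replacing the chloro on the other aromatic ring or to altering the side chain.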